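The source may report more compounds than this note shows. Statements on the series, on what has been measured and on what is new or still open speak of the compounds shown alone.

In a functional assay on MCF7 cells (Homo sapiens) for antiproliferative activity, read by MTT assay, with a stated time of 24 h (on this read-out lower numbers stand for stronger inhibition and higher numbers for weaker inhibition), compound 1 (`Cc1ccc(-c2nn(-c3ccccc3)cc2-c2nc3ccccc3n2S(=O)(=O)c2cc(C)ccc2C)cc1`) gives 510 nM and compound 2 (`COc1ccc(S(=O)(=O)n2c(-c3cn(-c4ccccc4)nc3-c3ccc(F)cc3)nc3ccccc32)cc1`) gives 530 nM while compound 3 (`O=[N+]([O-])c1ccc(S(=O)(=O)n2c(-c3cn(-c4ccccc4)nc3-c3ccc(F)cc3)nc3ccccc32)cc1`) gives 1370 nM as the highest of the three numbers. Compound 4 (`O=S(=O)(c1ccc(C(F)(F)F)cc1)n1c(-c2cn(-c3ccccc3)nc2-c2ccc(F)cc2)nc2ccccc21`) differs from compound 3 by trifluoromethyl in place of nitro on an aromatic carbon, para to a large group. Within the data shown here, the one measured step bearing on this is a 2.6-fold higher number from compound 2 to compound 3 (0.41 log units; beyond the scatter) on nitro in place of methoxy, and it is modest. With nitro leaving, a smaller move toward lower numbers in this assay is expected. The expected size is a 1.6-fold lower number from compound 3 to compound 4 (0.21 log units; within the scatter) and so no clear step beyond the scatter. For compound 4 the estimate is 850 nM (expected range 420 nM to 1750 nM).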

Compound 4, half-maximal inhibitory concentration: 1580 nM
Compound 4: the middle estimate sits 1.9-fold (0.27 log units) below what was measured; low and high end bracket the measured number.
By their numbers in this assay, from the lowest: compounds 1 and 2 (each within the scatter of the next); then compounds 3 and 4 (each within the scatter of the next).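

Placed para to a large group, trifluoromethyl in place of nitro gives a 1.2-fold higher number from compound 3 to compound 4 (0.06 log units; within the scatter) in this assay, so this change does not separate the two groups. Trifluoromethyl in place of methoxy gives a 3.0-fold higher number from compound 2 to compound 4 (0.47 log units; beyond the scatter), which shows that a second group at this position, besides nitro, reads apart from methoxy. No measurement shown accounts for these readings. The compounds shown leave open how an amine or a carboxylic acid at this position would read, and whether methoxy would keep its place among them.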